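Adding a Second Chloro Group to a Purine-Type Core

A few compounds are considered here, and "the series" means these few. Any claim that something is new, unique, unknown or untested is made for them only; others in the source may bear on it.

Compound 1 `ClCc1ccc(Cn2cnc3c(Cl)ncnc32)cc1`, compound 2 `ClCc1ccccc1Cn1cnc2ncnc(Cl)c21` and compound 3 `ClCc1ccc(Cn2cnc3c(Cl)nc(Cl)nc32)cc1` were tested in a functional assay on HCT-15 cells (Homo sapiens) for cytotoxicity, read by sulforhodamine B assay, with a stated time of 48 h; on this read-out lower numbers stand for stronger inhibition of growth and higher numbers for weaker inhibition of growth. Compound 1 gives 12600 nM, compound 3 gives 3800 nM and compound 2 gives 2880 nM. Compound 2 and compound 1 share the same atoms joined differently; the difference between their two cores is not broken down here. Compound 3 carries one change on the core of compound 1, (chloro in place of hydrogen on an aromatic carbon), and this step gave a 3.3-fold lower number from compound 1 to compound 3 (0.52 log units; beyond the scatter).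

Compound 4 `ClCc1ccccc1Cn1cnc2nc(Cl)nc(Cl)c21` carries the same change on the core of compound 2, (chloro in place of hydrogen on an aromatic carbon). The surroundings of the changed carbon are described in the same words for both pairs, so the change is the same one. The expectation for compound 4 therefore rests on the step that compound 3 made, a 3.3-fold lower number from compound 1 to compound 3 (0.52 log units; beyond the scatter), applied to the value of compound 2, 2880 nM. Compound 4 is expected to show a 2.5-fold lower number from compound 2 to compound 4 (0.40 log units; beyond the scatter). The estimate for compound 4 is 1150 nM, with a likely range from 500 nM to 2800 nM, and the measured number is awaited.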

Compound 4, concentration for total growth inhibition: 430 nM
For compound 4 the middle estimate is 2.7-fold (0.43 log units) above the measured one; measured number outside the range, below it.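

Putting a chloro group in place of hydrogen on the aromatic carbon between two ring nitrogen atoms again lowered the number in this assay, with a 6.7-fold lower number from compound 2 to compound 4 (0.83 log units; beyond the scatter). Set beside the earlier step, the change carried over from one core to the other in direction and, within the scatter, in size: the same change on two cores in this assay, a 3.3-fold lower number (0.52 log units; beyond the scatter) from compound 1 to compound 3 and a 6.7-fold lower number (0.83 log units; beyond the scatter) from compound 2 to compound 4, 2.0-fold (0.31 log units) apart, within the scatter of two such steps. Among the compounds shown here, this rests on only two pairs of compounds in one cell line, and it does not show that the step would hold on any further core or that the two cores truly respond differently.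

The compounds shown leave open whether another group on that same carbon, such as a bromo group, an amine or a methoxy group, would give a step like the one seen with chloro. They also leave open how the chloro step would read in other cell lines or over a different exposure time.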